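The source may report more compounds than this note shows. Statements on the series, on what has been measured and on what is new or still open speak of the compounds shown alone.

Three related compounds have been measured in a physicochemical assay for lipophilicity, at pH 7.4; on this read-out lower numbers stand for lower lipophilicity and higher numbers for higher lipophilicity. Compound 1 (`CC(C)CN(C1CCc2ccc(F)cc21)S(=O)(=O)c1ccc2c(c1)C(=O)CC(C1CCOCC1)O2`) gives 4.03, compound 2 (`CCc1ccc(N(CC(C)C)S(=O)(=O)c2ccc3c(c2)C(F)CC(C2CCOCC2)O3)cc1`) gives 5.02, and compound 3 (`CCc1ccc(N(CC(C)C)S(=O)(=O)c2ccc3c(c2)C(=O)CC(C(C)C2CCOCC2)O3)cc1`) gives 4.93. Compound 3 therefore sits within the scatter of compound 2, while compound 1 lies lower, beyond the scatter. No two of these compounds differ in one place only, so the data offer no measured step for the change now in question.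

Compound 4 (`CCc1ccc(N(CC(C)C)S(=O)(=O)c2ccc3c(c2)C(=O)CC(C2CCN(S(C)(=O)=O)CC2)O3)cc1`) departs from compound 3 on a saturated ring carbon, next to the ring oxygen, where 1-(methylsulfonyl)piperidin-4-yl stands in place of 1-(oxan-4-yl)ethyl: 1-(methylsulfonyl)piperidin-4-yl in place of 1-(oxan-4-yl)ethyl on a saturated ring carbon. Going by the values given here, with no measured precedent, the expectation rests on this structural change alone. A downward step in this assay is expected, and it is expected to lie beyond the scatter. The estimated step is a number 0.63 log units lower from compound 3 to compound 4 (beyond the scatter). For compound 4 the estimated value is 4.3, with an expected range of 3.8 to 4.7.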

Compound 4, distribution coefficient: 3.31
Estimate against measurement, compound 4: 0.99 log units above, outside the stated range (below it).
By their numbers in this assay, from the lowest: compound 4; then compound 1; then compounds 3 and 2 (each within the scatter of the next).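

In this assay, going by these compounds alone, 1-(methylsulfonyl)piperidin-4-yl in place of 1-(oxan-4-yl)ethyl gives a number 1.62 log units lower from compound 3 to compound 4 (beyond the scatter) as the first measured step at this position. The step is large, so the group on this saturated ring carbon, next to the ring oxygen, can strongly shift the read-out while the rest of the compound stays the same. The material shown offers no measurement that accounts for the size of this step.

The change replaces the whole group at once, so the compounds shown do not separate the contribution of the methylsulfonyl from that of the piperidine ring or of the lost ethyl link. As far as these compounds go, it remains open whether an acetyl group or a free ring amine on the piperidine would give a step of similar size.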